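From benzyl to 3-hydroxypropyl on the shared core

The source may hold more compounds than are shown below. What is called first, only, known or untested is meant among the compounds shown, and "the series" means these compounds.

Measured in a functional assay on MCF7 cells (Homo sapiens) for antiproliferative activity, read by sulforhodamine B assay, with a stated time of 48 h; on this read-out higher numbers stand for weaker inhibition and lower numbers for stronger inhibition:
- compound 1 `CC(=O)N[C@@H]1[C@@H](OC(C)=O)[C@H](OC(C)=O)[C@@H](COC(C)=O)O[C@H]1n1nc(-c2cc3ccccc3[nH]2)nc1SCc1ccccc1`: > 100 ug/mL, a limit of the assay and not a number
- compound 2 `c1ccc(CSc2nc(-c3cc4ccccc4[nH]3)n(Cc3ccccc3)n2)cc1`: 14.8 ug/mL

Within the data shown here, compound 2, at 14.8 ug/mL, holds the only true number so far, which leaves little to compare it with. Compound 3 `OCCCn1nc(SCc2ccccc2)nc1-c1cc2ccccc2[nH]1` keeps the shared core and differs from compound 2 in one place: 2-hydroxyethyl in place of phenyl on a saturated chain carbon bound to an aromatic nitrogen. There, 2-hydroxyethyl stands in place of phenyl on a saturated chain carbon bound to an aromatic nitrogen. Among the measured compounds shown here, no measured pair shows this change, so only a modest move toward weaker inhibition is expected, estimated as a 2.4-fold higher number from compound 2 to compound 3 (0.37 log units; beyond the scatter). For compound 3 the estimated value is 35 ug/mL, with an expected range from 12 ug/mL to 100 ug/mL.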

Compound 3, half-maximal inhibitory concentration: 16.2 ug/mL
Compound 3: the middle estimate sits 2.2-fold (0.33 log units) above what was measured, and the stated range covers the measured number.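

In this assay, among these compounds, the step is a 1.1-fold higher number from compound 2 to compound 3 (0.04 log units; within the scatter) and so the first real comparison at this place, a saturated chain carbon bound to an aromatic nitrogen, shows two compounds that read alike. The phenyl ring gives way to 2-hydroxyethyl, which has no ring, without a difference that stands out from the scatter. Nothing measured here explains why the two read alike. From the compounds shown here alone, whether an amine, a carboxylic acid or a longer chain at this place would also read alike stays open.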